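The compounds below may be only part of what the source reports. "The series", "measured", "known", "first", "only" and "open" are said of these compounds alone.

Measured in a functional assay on the whole organism for antagonist activity, with Mus musculus as the target; on this read-out higher numbers stand for an effect only at larger amounts of compound and lower numbers for an effect already at smaller amounts:
- Compound 1 `Cn1ccn(CC#CCN2CCCC2)c1=O`: > 10 mg/kg (a limit)
- Compound 2 `Cn1ccn(CC#CCn2ccnc2)c1=O`: > 100 mg/kg (a limit)

Compound 2 has no exact value, only the limit > 100 mg/kg. Compound 3 `CN(C)CC#CCn1ccn(C)c1=O` places dimethylamino in place of 1H-imidazol-1-yl on a saturated chain carbon bound to a triple-bonded carbon. Within the data shown here, the only measured step bearing on this change is a step that the two limits leave unreadable from compound 1 to compound 2, so it offers no usable size. Compound 1, with pyrrolidin-1-yl, is the nearer guide to an open-chain amino group, and its limit is > 10 mg/kg. A move toward smaller doses is therefore tentatively expected, with an at least 3.3-fold lower number from compound 2 to compound 3 (0.52 log units; beyond the scatter) as the estimated step in this assay. For compound 3 the estimate is 30 mg/kg, with an expected range of 8 mg/kg to 150 mg/kg.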

Compound 3, dose for half-maximal effect: > 100 mg/kg
Compound 3 gave a limit, no number (the forecaster's own chance of this, stated with the estimate: 65%); middle value at least 3.3-fold (0.52 log units) from the limit.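

In this assay, among these compounds, compound 1, compound 2 and compound 3 each give only a limit, so no step among them can be read. The compounds shown leave open whether dimethylamino, pyrrolidin-1-yl and 1H-imidazol-1-yl differ at all.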